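A few compounds are considered here, and "the series" means these few. Any claim that something is new, unique, unknown or untested is made for them only; others in the source may bear on it.

Compound 1 `O=C(O)CC/C=C\CO[C@@H]1C(OCc2ccc(-c3ccccc3)cc2)CC[C@@H]1N1CCCCC1` is a thromboxane receptor antagonist of the cyclopentane ether type. In a functional assay on blood for antagonist activity at thromboxane A2 receptor (Homo sapiens) (on this read-out higher numbers stand for weaker binding and lower numbers for tighter binding), compound 1 gives 39.8 nM, the only number shown for it, alongside one further entry that has no single value. Its partner compound 2 `O=C(O)CC/C=C\CO[C@H]1C(OCc2ccc(-c3ccccc3)cc2)CC[C@@H]1N1CCCCC1`, drawn with the opposite configuration at the defined ring centre, gives 63.1 nM; 15.9 nM (2 entries) in this assay; the spread between these entries the several entries of compound 2 in this assay, 63.1 nM; 15.9 nM (2 entries) shows how far repeats of this measurement can wander, and one of the two compounds is drawn with a defined configuration where the other is not (the fact that one of compounds 1 and 2 is drawn with a defined configuration and the other without, at the place where they differ).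

Compound 3 `O=C(O)CC/C=C\CO[C@@H]1[C@@H](OCc2ccc(-c3ccccc3)cc2)CC[C@@H]1N1CCCCC1` is not yet measured. It differs from compound 1 only in this: the two compounds have the same atoms and bonds; at least one stereo element is drawn with a configuration in one of them and without one in the other: 1 of 4 stereo elements differ; a stereocentre at a saturated ring carbon is drawn without a configuration in compound 1 and S in compound 3. Among the measured compounds shown here, since no measured pair shows such a step, the expected change from compound 1 to compound 3 is a 1.6-fold lower number from compound 1 to compound 3 (0.20 log units; within the scatter), a step still within the usual scatter. Compound 3 is therefore expected to give 25 nM, with a range from 8 nM to 80 nM.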

Compound 3, dissociation constant: 100 nM
The estimate for compound 3 lay 4.0-fold (0.60 log units) below the measured number; the measured number lies above the stated range.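

Drawing a defined S configuration at this saturated ring carbon is enough on its own to move the read-out in this assay: a 2.5-fold higher number from compound 1 to compound 3 (0.40 log units; beyond the scatter). This is the first step shown at this position, and it gives the first sign that the configuration at this carbon matters, since the atoms and bonds stay the same: the fact that one of compounds 1 and 3 is drawn with a defined configuration and the other without, at the place where they differ. The step is modest, and repeats in this measurement can spread widely, as a single compound shows: the several entries of compound 2 in this assay, 63.1 nM; 15.9 nM (2 entries).

The compounds shown leave open how the R configuration at this carbon would read with the rest of compound 3 unchanged. They also leave open whether the step would persist with an amide in place of the carboxylic acid.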